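Removing one methoxy group: what to expect for compound 4

The source may hold more compounds than are shown below. What is called first, only, known or untested is meant among the compounds shown, and "the series" means these compounds.

Compound 2 `COc1ccc(-c2cc(/C=C/C(=O)c3ccc(N)cc3)[nH]n2)cc1OC` gives 95% in a functional assay on NCI-H322M cells (Homo sapiens) for cytotoxicity, read by sulforhodamine B assay, with a stated time of 48 h, tested at 1 uM; a higher number here means a weaker effect of the compound at the concentration tested, a lower number a stronger effect. Compound 1 `COc1ccc(-c2cc(/C=C/C(=O)c3ccc(N)cc3)[nH]n2)cc1` gives 69% in this assay. The change between them is hydrogen in place of methoxy on an aromatic carbon, and the step is a number 26 percentage points lower from compound 2 to compound 1 (beyond the scatter).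

Compound 3 `COc1cc(C(=O)/C=C/c2cc(-c3cc(OC)c(OC)c(OC)c3)n[nH]2)cc(OC)c1OC` gives 89% in this assay; set against compound 2, that number lies within the scatter. The difference between the cores of compound 2 and compound 3 is not broken down here.

Compound 4 `COc1ccc(-c2cc(/C=C/C(=O)c3cc(OC)c(OC)c(OC)c3)[nH]n2)cc1OC` has not yet been measured in this assay. It differs from compound 3 by hydrogen in place of methoxy on an aromatic carbon. The two places are not the same word for word: in compound 3 the carbon that loses the methoxy is also meta to a methoxy group, which is not said of compound 2. It is therefore the same kind of change, not the same one.

The expected step is a number 23 percentage points lower from compound 3 to compound 4 (beyond the scatter), set beside a number 26 percentage points lower from compound 2 to compound 1 (beyond the scatter); this rests on compound 1, whose 69% follows the same kind of change. Compound 4 is estimated at 66%, between 45% and 87%.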

Compound 4, a percentage reported as activity, at one concentration (the size of the read-out at that concentration, not a potency): 82%
The estimate for compound 4 lay 16 percentage points below the measured number; the range from low to high includes it.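

On the core of compound 3, hydrogen in place of methoxy gives a number 7 percentage points lower from compound 3 to compound 4 (within the scatter) in this assay, so the clear step seen on the other core does not repeat here. The size of this step therefore depends on the core carrying it, at least for these two pairs: the same change on two cores in this assay, a number 26 percentage points lower (beyond the scatter) from compound 2 to compound 1 and a number 7 percentage points lower (within the scatter) from compound 3 to compound 4, 19 percentage points apart, beyond the scatter of two such steps This does not show which part of the cores sets the size of the step, and two pairs give no rule for a further core.

As far as these compounds go, at this place, only hydrogen and methoxy are compared, so it remains open how ethoxy or a chlorine atom would behave there on either core. Every number here is also a read-out at one concentration rather than a potency, which leaves open whether the two steps would still differ across a range of concentrations.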